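A few compounds are considered here, and "the series" means these few. Any claim that something is new, unique, unknown or untested is made for them only; others in the source may bear on it.

For the measured compounds named here, compound 1 `O=C(NCc1ccc(S(=O)(=O)c2ccccc2)cc1)c1cc2ncccc2s1` stands highest of the two numbers so far in an ADME assay on microsomes from liver (Homo sapiens) for metabolic stability, read by LC-MS, with a stated time of 30 min, tested at 1 uM (on this read-out higher numbers stand for a more stable compound and lower numbers for a less stable compound), where compound 1 gives 81%. Going by the values given here, the only other measured compound, compound 2 `O=C(NCc1ccc(S(=O)(=O)c2ccccc2C(F)(F)F)cc1)c1cc2cnccc2[nH]1`, gives 52% in this assay, a number lower than that of compound 1 by a gap beyond the usual scatter; the two structures differ in more than one place, so no single step between them can be drawn. Compound 3 `O=C(NCc1ccc(S(=O)(=O)c2ccccc2)cc1)c1nc2cnccc2[nH]1` has not yet been measured in this assay. It differs from compound 1 in one place: a group of 9 heavy atoms (6 carbon, 3 nitrogen; one five-membered aromatic ring with 2 hetero atoms, one six-membered aromatic ring with 1 hetero atom) in place of a group of 9 heavy atoms (7 carbon, 1 nitrogen, 1 sulfur; one five-membered aromatic ring with 1 hetero atom, one six-membered aromatic ring with 1 hetero atom), on a carbonyl carbon. Among the compounds with values here, no step between measured compounds mirrors this change, so its size is uncertain; the entering group shares a five-membered aromatic ring bearing a hydrogen-bond donor with the corresponding part of compound 2, whose value in this assay is the lower of the two. Compound 3 is therefore expected to fall below compound 1 by a step of a number 21 percentage points lower from compound 1 to compound 3 (beyond the scatter), of moderate size and downward. The estimate for compound 3 in this assay is 60%, with a range from 35% to 85%.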

Compound 3, percent of the compound remaining: 73%
For compound 3 the middle estimate is 13 percentage points below the measured one, within the range that was stated.
By their numbers in this assay, from the lowest: compound 2; then compounds 3 and 1 (each within the scatter of the next).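

For the compounds shown here, the first step that can be read at this place on a carbonyl carbon, whose other neighbour is an amide-type nitrogen, is a number 8 percentage points lower from compound 1 to compound 3 (within the scatter) in this assay and stands within the scatter. At this place, therefore, the group with a five-membered aromatic ring with 2 hetero atoms and 1 hydrogen-bond donor, carrying 3 nitrogen atoms and no sulfur, gives a number that cannot be told apart from that of the sulfur-bearing group it replaces, so on this single pair the exchange leaves the read-out without a resolved difference. Nothing measured here gives a reason for this result.

Going by these compounds alone, compound 2 differs from compound 1 in more than one place, so this single step does not say how much of its number belongs to its bicyclic group and how much to its trifluoromethyl group, and no step for the trifluoromethyl group alone can be read. Going by these compounds, it also remains open how this assay would respond to quite different groups on the same carbonyl carbon, such as a morpholine or an open alkyl chain.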